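Fluoro for methoxy on compound 3

The source may hold more compounds than are shown below. What is called first, only, known or untested is meant among the compounds shown, and "the series" means these compounds.

Values so far in a functional assay on MCF7 cells (Homo sapiens) for antiproliferative activity, read by MTT assay, with a stated time of 48 h (a higher number here means a weaker inhibitor, a lower number a stronger inhibitor), are these:
Compound 1 `COc1ccc(-c2c(Nc3ccc(F)cc3)c3ccc(OC)cc3oc2=O)cc1` gives > 100000 nM as a limit of the assay, not a number
Compound 2 `COc1ccc(-c2c(Nc3ccc(NC(C)=O)cc3)c3ccc(OC)cc3oc2=O)cc1` gives 85800 nM
Compound 3 `COc1ccc(Nc2c(C(=O)C(F)(F)F)c(=O)oc3cc(OC)ccc23)cc1` gives 55700 nM

Compound 3 holds the lowest of the two true numbers, but its value and that of compound 2 lie within the scatter of each other. The next compound is compound 4 `COc1ccc2c(Nc3ccc(F)cc3)c(C(=O)C(F)(F)F)c(=O)oc2c1` and it differs from compound 3 in one place, with fluoro in place of methoxy on an aromatic carbon, para to a large group. The counted difference is fluoro in place of methoxy on an aromatic carbon and it turns (4-methoxyphenyl)amino into (4-fluorophenyl)amino.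

Among the compounds with values here, only one measured step bears on this, and it changes a fluoro group too, on a different core. That step is an at least 1.1-fold lower number from compound 1 to compound 2 (0.06 log units; that floor lies within the scatter) and it gives no sign of a real effect. On these data alone, compound 1 stands at the limit of > 100000 nM in this assay, at which 1 of the 3 values shown sits, so the true size of that step stays unknown. The evidence therefore supports no expected change beyond the scatter in this assay and at most a slight lean toward a higher number. The expected step is a 1.2-fold higher number from compound 3 to compound 4 (0.07 log units; within the scatter) and no larger one is anticipated. For compound 4 the estimate is 65000 nM with 28000 nM and 100000 nM as the expected bounds.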

Compound 4, half-maximal inhibitory concentration: 9740 nM
Compound 4: the middle estimate sits 6.7-fold (0.82 log units) above what was measured; the measured number lies below the stated range.
By their numbers in this assay, from the lowest: compound 4; then compounds 3 and 2 (each within the scatter of the next). At a limit, above all of these: compound 1.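

In this assay, putting (4-fluorophenyl)amino where compound 3 carries (4-methoxyphenyl)amino gives a 5.7-fold lower number from compound 3 to compound 4 (0.76 log units; beyond the scatter), the first step among these compounds at this place that is printed as beyond the scatter, so on this core the group para to a large group does affect the read-out. With the (4-fluorophenyl)amino group held fixed, (trifluoromethyl)carbonyl in place of 4-methoxyphenyl gives an at least 10-fold lower number from compound 1 to compound 4 (1.01 log units; beyond the scatter), which shows that the same fluoro-bearing group can sit in a compound at the limit or in the compound with the lowest number, depending on that other place. That second step is only a floor because compound 1 is held at a limit of the assay, not a number: the limit of > 100000 nM in this assay, at which 1 of the 4 values shown sits.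

The compounds shown leave open whether the change follows from fluoro itself or from the loss of methoxy, and a chloro group, a nitrile or a plain hydrogen at the same place would separate these readings. On these data alone, it also stays open whether the methoxy-to-fluoro step carries over to the core of compound 1, where only fluoro and acetamido stand at this place.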